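Swapping the nitro for methylsulfanyl on the urea aryl ring

The source may report more compounds than this note shows. Statements on the series, on what has been measured and on what is new or still open speak of the compounds shown alone.

Compound 1: `O=C(Nc1ccc(Br)cc1)N[C@H]1CC[C@H](Oc2ccc(F)cc2)CC1` — > 20000 nM
Compound 2: `O=C(Nc1cccc([N+](=O)[O-])c1)N[C@H]1CC[C@H](Oc2ccc(F)cc2)CC1` — 6700 nM
Compound 3: `CSc1cccc(NC(=O)N[C@H]2CC[C@H](Oc3ccc(F)cc3)CC2)c1` — to be measured

Of the compounds shown here, two sharing the same core have been tested in a functional assay on CRL2813 cells (Homo sapiens) for cytotoxicity, read by sulforhodamine B assay, with a stated time of 5 days; on this read-out higher numbers stand for weaker inhibition and lower numbers for stronger inhibition. Compound 1 returns a limit of the assay, > 20000 nM, rather than a number. Going by the values given here, compound 2 gives 6700 nM in this assay and so holds the only number among the two values shown. Among the compounds with values here, the one measured step, an at least 2.9-fold lower number from compound 1 to compound 2 (0.47 log units; beyond the scatter), is therefore an open-ended one, resting on (the limit of > 20000 nM in this assay, at which 1 of the 2 values shown sits).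

Compound 3 differs from compound 2 at the same aryl ring: methylsulfanyl in place of nitro on an aromatic carbon. Within the data shown here, the only step recorded so far concerns a different exchange on that ring, so it speaks to compound 3 only in telling that a change of the substituent there can move the number beyond the scatter. The direction for methylsulfanyl in place of nitro is not given by anything measured.

Compound 3 is therefore expected to land near compound 2, with the step of a 1.2-fold higher number from compound 2 to compound 3 (0.08 log units; within the scatter) not expected to reach beyond the scatter. The estimate for compound 3 in this assay is 8000 nM, within 2500 nM to 25000 nM.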

Compound 3, half-maximal inhibitory concentration: 11100 nM
Compound 3: middle estimate off by 1.4-fold (0.14 log units), on the low side, within the range that was stated.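

Read in this assay, methylsulfanyl in place of nitro on an aromatic carbon gives a 1.7-fold higher number from compound 2 to compound 3 (0.22 log units; within the scatter), so at this place, meta to a large group, the two groups cannot be told apart, although they share no atom type. The second new comparison, for 3-(methylsulfanyl)phenyl in place of 4-bromophenyl on an amide-type nitrogen, gives an at least 1.8-fold lower number from compound 1 to compound 3 (0.25 log units; that floor lies within the scatter), so, unlike an at least 2.9-fold lower number from compound 1 to compound 2 (0.47 log units; beyond the scatter), it does not by itself separate the two compounds beyond the scatter. Compound 1 gives a limit and not a number, so both of its steps remain open-ended: the limit of > 20000 nM in this assay, at which 1 of the 3 values shown sits.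

The compounds shown leave open what an amine or a carboxylic acid would do on this aromatic carbon, and whether a longer chain such as ethylsulfanyl would keep the number in the same range as compound 2 and compound 3. Compound 1 also carries a different group at a different place on the ring, and the compounds shown do not tell the contribution of the group from that of its place.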